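Compound 3 to Compound 4: an Expected Step

The compounds below may be only part of what the source reports. "The series", "measured", "known", "first", "only" and "open" are said of these compounds alone.

For the measured compounds named here, compound 3 `C=C1C(=O)[C@]23C[C@@]1(O)CC[C@H]2c1ccc(OS(=O)(=O)c2ccc(C)cc2)c(C)c1[C@@H]3Cn1cc(-c2ccc(F)cc2)nn1` is the only member of this set with an actual number in a functional assay on SW480 cells (Homo sapiens) for cytotoxicity, read by MTT assay, with a stated time of 4 days; a lower number here means a stronger inhibitor, a higher number a weaker inhibitor: in this assay compound 3 gives 1630 nM. Compound 1 `C=C1C[C@]23C[C@@]1(O)CC[C@H]2c1ccc(OS(=O)(=O)c2ccc(C)cc2)c(C)c1[C@@H]3Cn1cc(-c2ccc(OC)cc2)nn1` reaches only a limit of this assay, > 20000 nM. Compound 2 `C=C1C[C@]23C[C@@]1(O)CC[C@H]2c1ccc(OS(=O)(=O)c2ccc(C)cc2)c(C)c1[C@@H]3Cn1cc(-c2ccccc2)nn1` likewise stops at a limit, > 20000 nM. The step that the two limits leave unreadable from compound 1 to compound 2 cannot be sized because of the limit of > 20000 nM in this assay, at which 2 of the 3 values shown sit, so it offers no guidance.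

Compound 4 `C=C1C(=O)[C@]23C[C@@]1(O)CC[C@H]2c1ccc(OS(=O)(=O)c2ccc(C)cc2)c(C)c1[C@@H]3Cn1cc(-c2ccccn2)nn1` differs from compound 3 by pyridin-2-yl in place of 4-fluorophenyl on an aromatic carbon. No measured step in this set touches that change; the one step shown concerns a different group and is itself unreadable. Compound 3 is therefore the sole anchor, and with nothing arguing for a move in either direction, the expectation is for a step no larger than the usual scatter. Compound 4 is expected to give 2500 nM in this assay, with a range from 800 nM to 8000 nM. The step this estimate implies, a 1.5-fold higher number from compound 3 to compound 4 (0.19 log units; within the scatter), is expected to stay within the scatter of repeated measurements.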

Compound 4, half-maximal inhibitory concentration: 1970 nM
The estimate for compound 4 lay 1.3-fold (0.10 log units) above the measured number; measured number inside the range.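

In this assay, for the compounds shown here, pyridin-2-yl in place of 4-fluorophenyl gives a 1.2-fold higher number from compound 3 to compound 4 (0.08 log units; within the scatter), the first step in this set that can be read at all. On this aromatic carbon of the five-membered aromatic ring, then, the assay does not tell apart a six-membered aromatic ring of carbon only with no hydrogen-bond acceptor from one with 1 hetero atom and 1 hydrogen-bond acceptor, at least for these two groups. The one earlier step, hydrogen in place of methoxy, cannot be read and so could not show this: the limit of > 20000 nM in this assay, at which 2 of the 4 values shown sit.

From the compounds shown here alone, what an amine, a carboxylic acid or a longer chain would do in this place stays open. So does whether pyridin-3-yl or pyridin-4-yl would read the same as pyridin-2-yl in this assay.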